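The compounds below may be only part of what the source reports. "The series", "measured", "known", "first", "only" and "open" are said of these compounds alone.

Going by the values given here, in an assay on CHO cells for binding affinity to integrin alpha-1 (Homo sapiens), read by WST assay, with a stated time of 2 h (a higher number here means that more compound is needed for the effect, a lower number that less compound is needed), compound 1 `O=C(c1ccccc1)c1ccc(NS(=O)(=O)c2ccc(Cl)cc2Cl)cc1` gives 20000 nM, and this is the only number reported among the three measured compounds. Compound 2 `CC(=O)c1cccc(NS(=O)(=O)c2ccc(Cl)cc2Cl)c1` gives "not active" (no number reported), and compound 3 `CN(c1ccc(C(=O)c2ccccc2)cc1)S(=O)(=O)c1ccc(Cl)cc1Cl` gives "not active" (no number reported), so neither adds a number to compare against. Compound 1 therefore stands alone as the single entry with a measured value, and that value already calls for a large amount of compound. Compound 4 `Cc1ccc(S(=O)(=O)Nc2ccc(C(=O)c3ccccc3)cc2)cc1` differs from compound 1 in one place: 4-methylphenyl in place of 2,4-dichlorophenyl on a sulfonyl sulfur. Among the compounds with values here, no step between two measured compounds of this kind is known, so nothing measured points the direction. The step is expected to be small and toward a higher number, a 1.5-fold higher number from compound 1 to compound 4 (0.18 log units; within the scatter). Compound 4 is estimated at 30000 nM, within a range from 10000 nM to 100000 nM, with a real chance that only a limit is reported.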

Compound 4, half-maximal effective concentration: "not active" (no number reported)
The entry for compound 4 holds no number; the estimate stays without a comparison.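

Going by these compounds alone, compound 4 carries no number, so no step from compound 1 to compound 4 can be read. No evidence bears on this result. The compounds shown leave open how 4-methylphenyl compares numerically with 2,4-dichlorophenyl.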